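The source may hold more compounds than are shown below. What is called first, only, known or untested is meant among the compounds shown, and "the series" means these compounds.

Measured compounds:
compound 1 `O=S(=O)(NCCCCCCNCc1ccc(Br)cc1)c1ccccc1Cl` — 13700 nM
compound 2 `CC(C)c1ccc(S(=O)(=O)NCCCCCCNCc2ccc(Br)cc2)cc1` — 5730 nM
compound 3 `O=S(=O)(NCCCCCCNCc1ccc(Br)cc1)c1ccc2c(c1)OCC2` — 13000 nM

In a functional assay on MIA PaCa-2 cells (Homo sapiens) for inhibition, read by MTT assay, with a stated time of 72 h (on this read-out lower numbers stand for stronger inhibition of growth and higher numbers for weaker inhibition of growth), compound 3 stands second highest of the three numbers; the two steps that end at it are a 1.1-fold lower number from compound 1 to compound 3 (0.02 log units; within the scatter), which lies within the scatter, and a 2.3-fold higher number from compound 2 to compound 3 (0.36 log units; beyond the scatter), which lies beyond it. Compound 4 `O=S(=O)(NCCCCCCNCc1ccc(Br)cc1)c1ccccc1F` differs from compound 3 as follows: a group of 7 heavy atoms (6 carbon, 1 fluorine; one six-membered aromatic ring of carbon only) in place of a group of 9 heavy atoms (8 carbon, 1 oxygen; one five-membered non-aromatic ring with 1 hetero atom, one six-membered aromatic ring of carbon only), on a sulfonyl sulfur. The step that bears most on this is compound 1 to compound 3, where 2-chlorophenyl against the leaving group gave a 1.1-fold lower number from compound 1 to compound 3 (0.02 log units; within the scatter); the 2-fluorophenyl of compound 4 is the nearest analogue of that 2-chlorophenyl. Among the compounds with values here, the only step beyond the scatter, a 2.4-fold lower number from compound 1 to compound 2 (0.38 log units; beyond the scatter), concerns 4-isopropylphenyl and does not apply here. No change beyond the scatter is therefore expected for compound 4, with a 1.1-fold higher number from compound 3 to compound 4 (0.03 log units; within the scatter) as the expected step. Compound 4 is estimated at 14000 nM, within 7000 nM to 30000 nM.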

Compound 4, concentration for 50% growth inhibition: 13300 nM
The estimate for compound 4 lay 1.1-fold (0.02 log units) above the measured number, within the range that was stated.
By their numbers in this assay, from the lowest: compound 2; then compounds 3, 4 and 1 (each within the scatter of the next).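

In this assay fluoro in place of chloro on an aromatic carbon gives a 1.0-fold lower number from compound 1 to compound 4 (0.01 log units; within the scatter) and so does not separate the two halogens at this place. On the sulfonyl sulfur, 2-fluorophenyl in place of the larger oxygen-bearing group gives a 1.0-fold higher number from compound 3 to compound 4 (0.01 log units; within the scatter) while replacing 4-isopropylphenyl gives a 2.3-fold higher number from compound 2 to compound 4 (0.37 log units; beyond the scatter) and leaves 4-isopropylphenyl alone apart from the other three groups. Nothing measured here accounts for these steps.

Still open, on these data alone, is whether an amine or a carboxylic acid on the phenyl ring would shift the number. Also open, as far as these compounds go, is whether tert-butylphenyl would follow 4-isopropylphenyl.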